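The source may report more compounds than this note shows. Statements on the series, on what has been measured and on what is new or still open speak of the compounds shown alone.

Measured compounds:
- compound 1, `COc1cc(-c2cc(/C=C/C(=O)c3ccc(Cl)c(Cl)c3)[nH]n2)cc(OC)c1OC`, in a functional assay on NCI-H226 cells (Homo sapiens) for cytotoxicity, read by sulforhodamine B assay, with a stated time of 48 h, tested at 1 uM; on this read-out lower numbers stand for a stronger effect and higher numbers for a weaker effect at the one concentration tested: 96%
- compound 2, `COc1ccc(C(=O)/C=C/c2cc(-c3cc(OC)c(OC)c(OC)c3)n[nH]2)cc1OC`, this assay: 89%

Compound 2 stands lowest of the two numbers in this assay; its nearest neighbour is compound 1, and the step of a number 7 percentage points lower from compound 1 to compound 2 (within the scatter) is within the scatter, so the two compounds cannot be told apart on this read-out.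

Compound 3, `COc1ccc(C(=O)/C=C/c2cc(-c3cc(OC)c(OC)c(OC)c3)n[nH]2)cc1`, is not yet measured in this assay. It differs from compound 2 by hydrogen in place of methoxy on an aromatic carbon.

Going by the values given here, no measured step bears directly on this change. Among the compounds with values here, the only step on record, a number 7 percentage points lower from compound 1 to compound 2 (within the scatter), alters the aryl group on the carbonyl carbon and stays within the scatter; it gives no indication that a change at that position moves the read-out. For this assay, therefore, no step beyond the scatter is expected from compound 2 to compound 3, and the estimated step is a number 3 percentage points higher from compound 2 to compound 3 (within the scatter).

Compound 3 is estimated in this assay at 92%, with a range from 80% to 103%.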

Compound 3, a percentage reported as activity, at one concentration (the size of the read-out at that concentration, not a potency): 92%
Compound 3: the middle estimate sits on the measured number at the digits printed; low and high end bracket the measured number.
By their numbers in this assay, from the lowest: compounds 2, 3 and 1 (each within the scatter of the next).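

In this assay, going by these compounds alone, going from 3,4-dimethoxyphenyl to 4-methoxyphenyl, with hydrogen in place of methoxy on an aromatic carbon, gives a number 3 percentage points higher from compound 2 to compound 3 (within the scatter) and so adds a first single-group change on this aryl ring that cannot be separated from the scatter. Comparison of the 3,4-dichlorophenyl and 4-methoxyphenyl groups on the carbonyl carbon gives a number 4 percentage points lower from compound 1 to compound 3 (within the scatter) in the same read-out, so all three aryl groups on that carbon, halogen-bearing or methoxy-bearing and with one or two methoxy groups, remain indistinguishable at the one concentration tested. No evidence is available on why these changes leave the read-out without a step beyond the scatter.

Still open, going by these compounds, is whether any group at this place can move the number beyond the scatter, for example an amine or a carboxylic acid in place of the methoxy group, or a longer alkoxy chain. On these data alone, the trimethoxy-substituted aryl group on the other side of the core is the same in all three compounds, so its contribution to this read-out also remains unknown.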